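The source may hold more compounds than are shown below. What is called first, only, known or untested is meant among the compounds shown, and "the series" means these compounds.

Measured compounds:
compound 1, `CCCCCCNc1[nH]ccc2ncnc1-2`: 100%
compound 2, `OC[C@H]1OC(n2cnc3c(Nc4ccccc4)nccc32)[C@H](O)[C@@H]1O`: 10%
compound 3, `OC[C@H]1O[C@@H](n2cnc3c(SCc4ccccc4)nccc32)C[C@@H]1O`: 11%

In a functional assay on EL4 cells (Mus musculus) for inhibition, tested at 100 uM (on this read-out higher numbers stand for more inhibition at the one concentration tested (going by the name of the read-out) and lower numbers for less inhibition), compound 1 gives 100%, the highest of the three numbers. Compound 3 comes nearest, and in this assay compound 3 gives 11%, which lies beyond the scatter below compound 1. Compound 2 sits furthest away; in this assay compound 2 gives 10%, also beyond the scatter below compound 1. Compounds 2 and 3 differ from compound 1 in more than one place, so their lower numbers cannot be tied to a single change.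

Compound 4, `CCNc1[nH]ccc2ncnc1-2`, has not yet been measured in this assay. It differs from compound 1 in one place: hydrogen in place of butyl on a saturated chain carbon, two bonds along the chain from a nitrogen on an aromatic ring. The hexyl chain of compound 1 is thereby shortened, the same difference read one bond further out being pentyl to methyl.

For the measured compounds named here, no step between measured compounds speaks to this change. Compound 1 gives 100%, a full read-out, so the shorter chain is expected to hold a large part of it. The step from compound 1 to compound 4 in this assay is estimated as a number 30 percentage points lower from compound 1 to compound 4 (beyond the scatter), a drop beyond the scatter but not to the level of compounds 2 and 3. For compound 4 the inhibition expected in this assay is 70%, within a range from 35% to 100%.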

Compound 4, a percentage reported as inhibition, at one concentration (the size of the read-out at that concentration, not a potency): < 5%
Compound 4 was reported as a limit; the forecaster's own chance of this, stated with the estimate: 0%; middle value at least 65 percentage points away from the limit.
By their numbers in this assay, from the lowest: compounds 2 and 3 (each within the scatter of the next); then compound 1. At a limit, below all of these: compound 4.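

Read in this assay, hydrogen in place of butyl on a saturated chain carbon, two bonds along the chain from a nitrogen on an aromatic ring, gives a number at least 95 percentage points lower from compound 1 to compound 4 (beyond the scatter), the only step among the compounds shown that ties a change in the read-out to a single place. Compound 4 stands at < 5%, which is a limit of the assay and not a number. The read-out at the one concentration tested therefore depends strongly on the length of the chain at this position, and the step has a bound rather than an exact size: the limit of < 5% in this assay, at which 1 of the 4 values shown sits.

The compounds shown leave open where along the chain the inhibition falls away, which a propyl or butyl chain on the same core would show. They also leave open whether an octyl chain, or a hexyl chain ending in an amine, would hold the read-out of compound 1.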